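This account rests on a few compounds, and the source may have more. Where it says the series, first, only, none or still open, it means among the compounds named here.

Going by the values given here, compound 1, with the structure `Oc1ccc(-c2cc(-c3ccc(O)cc3)nc(-c3ccc(O)cc3)c2)cc1`, is one of two compounds measured in a functional assay on T47D cells (Homo sapiens) for cytotoxicity, read by CCK-8 assay, with a stated time of 4 days (a higher number here means a weaker inhibitor, a lower number a stronger inhibitor), where compound 1 gives 4270 nM. Compound 2, with the structure `Oc1cccc(-c2cc(-c3cccc(O)c3)nc(-c3cccc(O)c3)c2)c1`, differs in carrying its hydroxyl groups in another place on each of the three outer rings, and in this assay compound 2 gives 2050 nM. Of the two numbers, that of compound 1 is the higher, and the gap to compound 2 lies beyond the scatter, so compound 1 is the weaker of the two measured inhibitors.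

Compound 3, with the structure `Oc1ccc(-c2cc(-c3ccccc3O)cc(-c3ccc(O)cc3)n2)cc1`, keeps the same atoms as compound 1 but joins them differently: 2-hydroxyphenyl in place of 4-hydroxyphenyl on an aromatic carbon. Only one of the three outer rings is touched, the one opposite the ring nitrogen and meta to two 4-hydroxyphenyl groups. Among the compounds with values here, since no pair of measured compounds shows the effect of this particular change, the expected step from compound 1 to compound 3 is a 1.2-fold lower number from compound 1 to compound 3 (0.09 log units; within the scatter), that is, a modest move, no larger than the scatter, in either direction. On that basis compound 3 is estimated at 3500 nM, with a plausible range from 1200 nM to 10000 nM.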

Compound 3, half-maximal inhibitory concentration: 5350 nM
Beside the measured number, compound 3's estimate is 1.5-fold (0.18 log units) below it; the range from low to high includes it.
By their numbers in this assay, from the lowest: compound 2; then compounds 1 and 3 (each within the scatter of the next).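

Putting 2-hydroxyphenyl in place of 4-hydroxyphenyl on the outer ring opposite the ring nitrogen gives a 1.3-fold higher number from compound 1 to compound 3 (0.10 log units; within the scatter) in this assay, so compound 1 and compound 3 cannot be told apart here. The earlier pair differed on all three outer rings at once, whereas this step touches only one, and it shows that on this ring the two hydroxyl placements give numbers within the scatter of each other. No measurement at hand accounts for this outcome.

As far as these compounds go, it remains open whether this ring needs a hydroxyl at all, and whether a plain phenyl, a methoxyphenyl or an aminophenyl at the same position would read any differently. Also open, from the compounds shown here alone, is how much each outer ring contributes to the number of compound 2, whose hydroxyl placement would have to be tried on one ring at a time to separate the three rings.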